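The source may hold more compounds than are shown below. What is called first, only, known or untested is meant among the compounds shown, and "the series" means these compounds.

Compound 1 `CCN(C(=O)CN(c1cc2c(C)nsc2cc1Cl)S(=O)(=O)c1ccc(OC)c(OC)c1)c1ccccn1`: 8 nM
Compound 2 `CCN(CC)C(=O)CN(c1cc2c(C)nsc2cc1Cl)S(=O)(=O)c1ccc(OC)c(OC)c1`: 29 nM
Compound 3 `CCN(C(=O)CN(c1cc(N(C)C)ccc1Cl)S(=O)(=O)c1ccc(OC)c(OC)c1)c1cccc(C)n1`: 17 nM

In a functional assay on CHO cells for inhibition of Orexin/Hypocretin receptor type 1 (Homo sapiens), read by FLIPR and calcium flux (a lower number here means a stronger inhibitor, a higher number a weaker inhibitor), compound 2 gives the highest of the three numbers; compound 3 lies within the scatter of it, compound 1 beyond it. Among the compounds with values here, the only counted step is a 3.6-fold higher number from compound 1 to compound 2 (0.56 log units; beyond the scatter), a change on the amide-type nitrogen. Compound 4 `CCN(CC)C(=O)CN(c1cc(N(C)C)ccc1C#N)S(=O)(=O)c1ccc(OC)c(OC)c1` is unmeasured and differs from compound 2 by a group of 11 heavy atoms (9 carbon, 2 nitrogen; one six-membered aromatic ring of carbon only) in place of a group of 11 heavy atoms (8 carbon, 1 nitrogen, 1 sulfur, 1 chlorine; one five-membered aromatic ring with 2 hetero atoms, one six-membered aromatic ring of carbon only), on a sulfonamide nitrogen. Within the data shown here, no measured step alters the group on the sulfonamide nitrogen, so the step from compound 1 to compound 2 does not bear on this change. Compound 3 carries a dimethylamino-substituted phenyl on that nitrogen and gives 17 nM, within the scatter of compound 2, though its amide substituent also differs. With that weak guide, compound 4 is expected to stay close to compound 2, the estimated step being a 1.2-fold higher number from compound 2 to compound 4 (0.08 log units; within the scatter). Compound 4 is therefore estimated at 35 nM, between 10 nM and 120 nM.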

Compound 4, half-maximal inhibitory concentration: 166 nM
For compound 4 the middle estimate is 4.7-fold (0.68 log units) below the measured one; the whole stated range lies below it.
By their numbers in this assay, from the lowest: compound 1; then compounds 3 and 2 (each within the scatter of the next); then compound 4.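

In this assay, the group on the sulfonamide nitrogen proves sensitive to change: 2-cyano-5-(dimethylamino)phenyl in place of the earlier group gives a 5.7-fold higher number from compound 2 to compound 4 (0.76 log units; beyond the scatter), a step beyond the scatter. Activity in this series therefore depends on this position as well as on the amide-type nitrogen. No measurement shown accounts for the step.

Because the whole group changes at once, the separate contributions of its nitrile and dimethylamino group remain unresolved. Also open, on these data alone, is how a fluorine or methoxy group in place of the nitrile would read.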